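This account rests on a few compounds, and the source may have more. Where it says the series, first, only, none or still open, it means among the compounds named here.

Within the data shown here, compound 3 `CC(C)(C)c1ccc(NC(=O)c2ccc(-c3ncccc3NC3CCCC3)cc2)cc1` gives 190 nM in a functional assay for antagonist activity at transient receptor potential cation channel subfamily V member 1 (Homo sapiens), read by FLIPR (on this read-out higher numbers stand for weaker inhibition and lower numbers for stronger inhibition), the highest of the three numbers measured so far, although compound 2 `CCCNc1cccnc1-c1ccc(C(=O)Nc2ccc(C(C)(C)C)cc2)cc1` at 158 nM lies within the usual scatter of it. Compound 1 `CC(C)(C)c1ccc(NC(=O)c2ccc(-c3ncccc3F)cc2)cc1` gives 3 nM, far lower. Compound 4 `CC(C)(C)c1ccc(NC(=O)c2ccc(-c3ncccc3N(S(C)(=O)=O)S(C)(=O)=O)cc2)cc1` carries bis(methylsulfonyl)amino in place of cyclopentylamino on an aromatic carbon. Among the measured compounds shown here, two measured steps bear on this position: a 53-fold higher number from compound 1 to compound 2 (1.72 log units; beyond the scatter) and a 63-fold higher number from compound 1 to compound 3 (1.80 log units; beyond the scatter), both large, while a 1.2-fold higher number from compound 2 to compound 3 (0.08 log units; within the scatter) shows no difference beyond the scatter between two amino substituents. A bis(methylsulfonyl)amino group, with no hydrogen-bond donor and four acceptors, has no direct precedent among these compounds, so only a modest further rise is expected, a 2.1-fold higher number from compound 3 to compound 4 (0.32 log units; beyond the scatter). Compound 4 is therefore estimated at 400 nM, with a likely range from 100 nM to 3000 nM.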

Compound 4, half-maximal inhibitory concentration: 0.8 nM
Compound 4: middle estimate off by 500-fold (2.70 log units), on the high side; measured number outside the range, below it.
By their numbers in this assay, from the lowest: compound 4; then compound 1; then compounds 2 and 3 (each within the scatter of the next).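

In this assay, bis(methylsulfonyl)amino on this aromatic carbon gives a 240-fold lower number from compound 3 to compound 4 (2.38 log units; beyond the scatter) and a 200-fold lower number from compound 2 to compound 4 (2.30 log units; beyond the scatter), so the high numbers of the two amino compounds do not hold for every group attached through nitrogen here. Against fluoro, the same group gives a 3.8-fold lower number from compound 1 to compound 4 (0.57 log units; beyond the scatter), so a low number at this position does not depend on fluoro alone. No measurement shown accounts for these differences. As far as these compounds go, whether both methylsulfonyl groups are needed remains open. A single methylsulfonylamino group, which keeps a hydrogen on the nitrogen, would test this.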